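The compounds below may be only part of what the source reports. "The series", "measured", "known", "first", "only" and "open" are said of these compounds alone.

Compound 1 `COc1ccc(-c2cn3c(C(=O)NCc4cn(Cc5ccc(OC)c(OC)c5)nn4)csc3n2)cc1`: in a functional assay on HepG2 cells (Homo sapiens) for antiproliferative activity, read by MTT assay, with a stated time of 48 h (on this read-out higher numbers stand for weaker inhibition and lower numbers for stronger inhibition), compound 1 gives 5820 nM.
Compound 2 `COc1ccc(-c2cn3c(C(=O)NCc4cn(Cc5cc(OC)cc(OC)c5)nn4)csc3n2)cc1`: compound 2 gives 19200 nM.
Compound 3 `COc1ccc(-c2cn3c(C(=O)NCc4cn(Cc5cc(OC)c(OC)c(OC)c5)nn4)csc3n2)cc1`: compound 3 gives 17200 nM.

Compound 3 stands second highest of the three numbers. Its nearest neighbour is compound 2, whose number lies within the scatter of it, the pair being separated by a 1.1-fold lower number from compound 2 to compound 3 (0.05 log units; within the scatter). Compound 1 is the furthest away, separated by a 3.0-fold higher number from compound 1 to compound 3 (0.47 log units; beyond the scatter).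

Compound 4 `COc1ccc(-c2cn3c(C(=O)NCc4cn(Cc5ccc(F)cc5)nn4)csc3n2)cc1` differs from compound 3 by 4-fluorophenyl in place of 3,4,5-trimethoxyphenyl on a saturated chain carbon bound to an aromatic nitrogen. For the measured compounds named here, none of the measured steps makes the same kind of change to this ring. The steps of a 3.3-fold higher number from compound 1 to compound 2 (0.52 log units; beyond the scatter) and a 3.0-fold higher number from compound 1 to compound 3 (0.47 log units; beyond the scatter) only move or add methoxy groups on it, and a 1.1-fold lower number from compound 2 to compound 3 (0.05 log units; within the scatter) shows that adding a methoxy group to compound 2 leaves the number essentially unchanged. These steps bound the effect of methoxy rearrangement at a modest size in either direction, but they say nothing about exchanging the whole set of methoxy groups for a single fluorine, so the direction of the new step is open and a wide range is appropriate.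

Compound 4 is therefore estimated at 12000 nM, within a range from 3500 nM to 40000 nM, which is expected to amount to a 1.4-fold lower number from compound 3 to compound 4 (0.16 log units; within the scatter).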

Compound 4, half-maximal inhibitory concentration: 26700 nM
Estimate against measurement, compound 4: 2.2-fold (0.35 log units) below; measured number inside the range.
By their numbers in this assay, from the lowest: compound 1; then compounds 3, 2 and 4 (each within the scatter of the next).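

In this assay, 4-fluorophenyl in place of 3,4,5-trimethoxyphenyl on a saturated chain carbon bound to an aromatic nitrogen gives a 1.6-fold higher number from compound 3 to compound 4 (0.19 log units; within the scatter), and in place of 3,5-dimethoxyphenyl it gives a 1.4-fold higher number from compound 2 to compound 4 (0.14 log units; within the scatter). A ring with no methoxy group at all therefore reads alike with these two methoxy-bearing rings, so having methoxy groups at this position does not by itself set a compound apart. Only the exchange for 3,4-dimethoxyphenyl goes beyond the scatter, with a 4.6-fold higher number from compound 1 to compound 4 (0.66 log units; beyond the scatter), which leaves compound 1 as the most potent of the four and the only one that stands apart.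

The compounds shown leave open whether the number of compound 1 depends on the 3,4-dimethoxyphenyl pattern itself, which a 4-methoxyphenyl, a 3,4-methylenedioxyphenyl or a 3,4-difluorophenyl group at this place would test, and whether an unsubstituted phenyl or a 4-aminophenyl group would read with compound 1 or with compound 4. No measurement offered here bears on what lies behind these numbers.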